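This account rests on a few compounds, and the source may have more. Where it says the series, first, only, none or still open, it means among the compounds named here.

Compound 1 `CCOc1ccc(OC(F)(F)F)cc1Cn1c(C(=O)NCC(C)(C)CO)cc2cc(C#N)ccc21` gives 103 mL.min-1.g-1
Compound 2 `COc1ccc(Cl)cc1Cn1c(C(=O)NCC(C)(C)CO)cc2cc(C#N)ccc21` gives 63 mL.min-1.g-1

Among the compounds with values here, both compounds were measured in an in vitro ADME assay on microsomes from Gut (Homo sapiens) for metabolic stability, in the presence of a further agent that is not named here (a higher number here means faster removal of the compound, a lower number slower removal), and compound 2, at 63 mL.min-1.g-1, stands within the scatter of compound 1, the only other compound with a number. Compound 3 `Cc1ccc(Cl)cc1Cn1c(C(=O)NCC(C)(C)CO)cc2cc(C#N)ccc21` has yet to be measured in this assay. The change from compound 2 to compound 3, (methyl in place of methoxy on an aromatic carbon), is methyl in place of methoxy on an aromatic carbon, ortho to a large group and para to a chloro group. Within the data shown here, no step between measured compounds that differ in one place is available, so the data give no guide to the size or direction of this one. The expected step, a 1.0-fold higher number from compound 2 to compound 3 (0.01 log units; within the scatter), is none beyond the scatter. For compound 3 the estimate is 65 mL.min-1.g-1, with an expected range from 32 mL.min-1.g-1 to 130 mL.min-1.g-1 in this measurement.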

Compound 3, intrinsic clearance in microsomes: 124 mL.min-1.g-1
The estimate for compound 3 lay 1.9-fold (0.28 log units) below the measured number, within the range that was stated.
By their numbers in this assay, from the lowest: compounds 2, 1 and 3 (each within the scatter of the next).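

In this assay, the change from 5-chloro-2-methoxyphenyl to 5-chloro-2-methylphenyl gives the first step that can be read at this position, a 2.0-fold higher number from compound 2 to compound 3 (0.29 log units; within the scatter), so this swap on an aromatic carbon, ortho to a large group and para to a chloro group, has not been shown to move the number beyond the scatter. The swap takes away one oxygen and one hydrogen-bond acceptor, and a single pair cannot show whether either loss matters here. No measurement is available that bears on the cause of this step.

The compounds shown leave open how a fluoro group, a hydroxyl group or an amine at this position would read. On these data alone, compound 1 differs from compound 2 in more than one place, so whether the step holds with another group in place of the chloro group also stays open.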